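The source may hold more compounds than are shown below. What is called first, only, known or untested is meant among the compounds shown, and "the series" means these compounds.

Measured so far:
Compound 1, `C=CC(=O)N1CC[C@H](N2C(=O)N(c3ccccc3)Cc3cnc(Nc4cccc(N5CCN(C)CC5)c4)nc32)C1`: 565 mL/min/kg
Compound 2, `C=CC(=O)N1CC[C@H](N2C(=O)N(c3ccccc3)Cc3cnc(Nc4ccc(N5CCN(C)CC5)c(OC)c4)nc32)C1`: 467 mL/min/kg
Compound 3, `C=CC(=O)N1CC[C@H](N2C(=O)N(Cc3ccccc3)Cc3cnc(Nc4ccc(N5CCN(C)CC5)cc4OC)nc32)C1`: 1040 mL/min/kg

All three were tested in an ADME assay on the whole organism (strain Sprague-Dawley) for pharmacokinetics, with Rattus norvegicus as the target, read by LC-MS, at a dose of 25 mg/kg by the oral route; a higher number here means faster removal of the compound, a lower number slower removal. Compound 2 gives the lowest number of the three. Its number and that of compound 1 lie within the scatter of each other, so the two cannot be told apart. Compound 3 stands beyond the scatter above compound 2, but compound 3 differs from compound 2 in more than one place, so that pair alone explains nothing. Compound 4, `C=CC(=O)N1CC[C@H](N2C(=O)N(c3ccccc3)Cc3cnc(Nc4ccc(N5CCN(C)CC5)cc4)nc32)C1`, has not yet been tested in this assay. It differs from compound 2 in one place: hydrogen in place of methoxy on an aromatic carbon. Within the data shown here, no measured pair isolates this change, so only a small step in this assay is expected, within the scatter and in no firm direction. Compound 4 is expected to give about 500 mL/min/kg, likely between 250 mL/min/kg and 1000 mL/min/kg. The step this estimate implies, a 1.1-fold higher number from compound 2 to compound 4 (0.03 log units; within the scatter), is expected to stay within the scatter.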

Compound 4, clearance: 203 mL/min/kg
Compound 4: the middle estimate sits 2.5-fold (0.39 log units) above what was measured; measured number below the stated range.
By their numbers in this assay, from the lowest: compound 4; then compounds 2, 1 and 3 (each within the scatter of the next, the first and the last beyond it).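

In this assay, hydrogen in place of methoxy on the aromatic carbon ortho to the 4-methylpiperazin-1-yl group gives a 2.3-fold lower number from compound 2 to compound 4 (0.36 log units; beyond the scatter) and so means slower removal. Among these compounds, this is the first pair differing in only one place, and it shows that this position is not indifferent to what sits on it. Nothing at hand explains the drop. Going by these compounds, whether a fluorine or an ethoxy group here would behave like hydrogen or like methoxy remains open. So does whether this step would repeat on the benzyl-bearing core of compound 3.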